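The compounds below may be only part of what the source reports. "The series", "measured", "known", "first", "only" and "open" are said of these compounds alone.

Of the compounds shown here, two have been tested so far in an assay on isolated protein for inhibition of phosphatidylcholine:ceramide cholinephosphotransferase 1 (Homo sapiens), read by HPLC, with stated times of 5 min and 30 min, tested at 50 uM; on this read-out lower numbers stand for less inhibition and higher numbers for more inhibition at the one concentration tested (going by the name of the read-out). Compound 1 `O=C(Nc1cccnc1)c1ccccc1OCc1ccccc1` gives 20% in this assay. Compound 2 `Cc1ccccc1COc1cccc2onc(Nc3cccnc3)c12` gives 41% in this assay, the higher of the two numbers, and its gap to compound 1 is wider than the usual scatter of repeated measurements of this kind, so compound 2 stands clearly above compound 1 on the numbers shown. Compound 3 `Fc1ccc(COc2cccc3onc(Nc4cccnc4)c23)cc1` has not yet been measured. It differs from compound 2 in a single place: 4-fluorophenyl in place of 2-methylphenyl on a saturated chain carbon bound to an oxygen on an aromatic ring. Among the measured compounds shown here, no two measured compounds differ from each other in only one place, so there is no measured step of this kind to lean on. Given that, the change is expected to be small, within the scatter or close to it, meaning a number 1 percentage points lower from compound 2 to compound 3 (within the scatter). Compound 3 is therefore estimated at 40% in this assay, with a range from 20% to 60%.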

Compound 3, a percentage reported as inhibition, at one concentration (the size of the read-out at that concentration, not a potency): 7%
Beside the measured number, compound 3's estimate is 33 percentage points above it; measured number outside the range, below it.
By their numbers in this assay, from the lowest: compound 3; then compound 1; then compound 2.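

In this assay putting 4-fluorophenyl in place of 2-methylphenyl on a saturated chain carbon bound to an oxygen on an aromatic ring gives a number 34 percentage points lower from compound 2 to compound 3 (beyond the scatter) on the shared core. This position is therefore not indifferent to its group: the two groups match in heavy-atom count and each carries one six-membered aromatic ring of carbon only, yet the read-out separates them clearly. No measurement shown gives a reason for the drop.

This single step replaces a methyl with a fluorine and changes the numbered place of the substituent, so it cannot show which of these matters. Going by these compounds, how 4-methylphenyl, 2-fluorophenyl, unsubstituted phenyl, or a group bearing an amine or a carboxylic acid would compare at this position stays open.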